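The source may report more compounds than this note shows. Statements on the series, on what has been measured and on what is new or still open speak of the compounds shown alone.

In a functional assay on DU-145 cells (Homo sapiens) for inhibition, read by trypan blue exclusion, with a stated time of 96 h (a lower number here means a stronger inhibitor of growth, a higher number a weaker inhibitor of growth), compound 1 (`O=C(/C(=C\c1ccc(Cl)cc1)S(=O)(=O)c1ccc(Br)cc1)c1ccc(Br)cc1`) gives 50000 nM and stands highest of the two numbers in hand. Compound 2 (`O=C(/C(=C\c1ccc(Br)cc1)SCc1ccc(Cl)cc1)c1ccc(Br)cc1`) gives 1000 nM and lies lower by a gap beyond the scatter. Compound 3 (`COc1ccc(/C=C(\C(=O)c2ccc(Br)cc2)S(=O)(=O)c2ccc(Br)cc2)c(F)c1`) is still unmeasured and keeps the core of compound 1 with one exchange (2-fluoro-4-methoxyphenyl in place of 4-chlorophenyl on a double-bonded chain carbon bound to a double-bonded chain carbon), namely 2-fluoro-4-methoxyphenyl in place of 4-chlorophenyl on a double-bonded chain carbon bound to a double-bonded chain carbon. Among the measured compounds shown here, no measured pair shows this exchange, so the expectation in this assay is loose. A lower number is expected because compound 1 at 50000 nM already sits at the top of the range seen. An estimated 4.2-fold lower number from compound 1 to compound 3 (0.62 log units; beyond the scatter) is taken as a moderate step, though a result within the scatter remains possible. For compound 3 the estimate is 12000 nM with 3000 nM and 50000 nM as the expected lower and upper ends.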

Compound 3, concentration for 50% growth inhibition: 10000 nM
Estimate against measurement, compound 3: 1.2-fold (0.08 log units) above, within the range that was stated.
By their numbers in this assay, from the lowest: compound 2; then compound 3; then compound 1.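

In this assay the exchange of 4-chlorophenyl for 2-fluoro-4-methoxyphenyl on a double-bonded chain carbon bound to a double-bonded chain carbon gives a 5.0-fold lower number from compound 1 to compound 3 (0.70 log units; beyond the scatter) and shows that the number responds to the group at this position, which compound 1 and compound 2 could not show, as they differ in more than one place. The step belongs to the exchange as a whole: fluoro and methoxy enter together, and their shares cannot be separated. No measurement at hand accounts for the step.

Still open, going by these compounds, is whether 4-methoxyphenyl or 2-fluorophenyl alone would give the same number, and whether a dimethylamino or a carboxylic acid group on this ring would move it further. Also open, on these data alone, is whether the same exchange gives a similar step on the core of compound 2.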